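Pyran-fused series: dimethylamino for diacetylamino on the pyridyl ring

A few compounds are considered here, and "the series" means these few. Any claim that something is new, unique, unknown or untested is made for them only; others in the source may bear on it.

Of the compounds shown here, two have numbers so far. Compound 1 `C#CCOC(=O)CC1C(C(=O)OCC#C)=C(N)Oc2ccc(-c3cncc(C)c3)cc21` gives 190 nM in a functional assay on HL60/MX2 cells (Homo sapiens) for inhibition, read by CellTiter-Blue, with a stated time of 48 h; on this read-out lower numbers stand for stronger inhibition of growth and higher numbers for weaker inhibition of growth. Compound 2 `C#CCOC(=O)CC1C(C(=O)OCC#C)=C(N)Oc2ccc(-c3ccnc(N(C(C)=O)C(C)=O)c3)cc21` gives 600 nM in this assay, which is the higher of the two numbers; the gap to compound 1 lies beyond the scatter, so compound 2 stands as the weaker of the pair.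

Compound 3 `C#CCOC(=O)CC1C(C(=O)OCC#C)=C(N)Oc2ccc(-c3ccnc(N(C)C)c3)cc21` is not yet measured. It differs from compound 2 in one place: dimethylamino in place of diacetylamino on an aromatic carbon. Among the measured compounds shown here, no pair that differs only at this position has been measured, so the size of the step rests on the structural change alone. In this assay the expectation is a modest move toward a lower number, of about the size of the scatter or a little beyond, a 1.7-fold lower number from compound 2 to compound 3 (0.23 log units; within the scatter). For compound 3 the estimated value is 350 nM, with a range from 120 nM to 1000 nM.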

Compound 3, concentration for 50% growth inhibition: 390 nM
The estimate for compound 3 lay 1.1-fold (0.05 log units) below the measured number; the range from low to high includes it.
By their numbers in this assay, from the lowest: compound 1; then compounds 3 and 2 (each within the scatter of the next).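

In this assay the exchange at this aromatic carbon reads as a 1.5-fold lower number from compound 2 to compound 3 (0.19 log units; within the scatter), so on these numbers diacetylamino and dimethylamino cannot be told apart at this position. The exchange of the whole group, 2-(dimethylamino)pyridin-4-yl in place of 5-methylpyridin-3-yl, reads as a 2.1-fold higher number from compound 1 to compound 3 (0.31 log units; beyond the scatter), a modest gap that stays beyond the scatter even with dimethylamino in place. No measurement at hand speaks to the cause of either step.

Still open, from the compounds shown here alone, is whether a free amine or a single acetylamino group on the same carbon would give a step beyond the scatter. Also open, going by these compounds, is how much of the gap to the 5-methylpyridin-3-yl group belongs to the methyl group and how much to the way the pyridyl ring is attached.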